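The source may report more compounds than this note shows. Statements on the series, on what has been measured and on what is new or still open speak of the compounds shown alone.

Compounds measured in a functional assay on HT-29 cells (Homo sapiens) for antiproliferative activity, read by sulforhodamine B assay, with a stated time of 48 h; a higher number here means a weaker inhibitor, a lower number a stronger inhibitor:
compound 1 `COc1ccc(NS(=O)(=O)c2ccc(N3CCNC3=O)cc2)cc1` gives 800 nM
compound 2 `O=C1NCCN1c1ccc(S(=O)(=O)Nc2ccc(OC(F)F)cc2)cc1` gives 650 nM
compound 3 `O=C1NCCN1c1ccc(S(=O)(=O)Nc2ccc(F)c(F)c2)cc1` gives 350 nM

Compound 2 stands second highest of the three numbers. The gap to compound 1 is within the scatter a 1.2-fold lower number from compound 1 to compound 2 (0.09 log units; within the scatter), and the gap to compound 3 is also within the scatter on the two values shown. Within the data shown here, the only step beyond the scatter is from compound 1 to compound 3 a 2.3-fold lower number from compound 1 to compound 3 (0.36 log units; beyond the scatter), a modest one.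

Compound 4 `O=C1NCCN1c1ccc(S(=O)(=O)Nc2ccccc2)cc1` differs from compound 2 as follows: hydrogen in place of difluoromethoxy on an aromatic carbon. Among the measured compounds shown here, no measured step removes the para group outright. The step from compound 1 to compound 2 a 1.2-fold lower number from compound 1 to compound 2 (0.09 log units; within the scatter) shows that altering the group on that oxygen leaves this assay unchanged within the scatter, while the step from compound 1 to compound 3 shows only a modest shift for a larger change of the aryl group. The expected step from compound 2 to compound 4 is therefore a 1.2-fold higher number from compound 2 to compound 4 (0.09 log units; within the scatter), none beyond the scatter. Compound 4 is estimated at 800 nM, range 350 nM to 1800 nM.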

Compound 4, half-maximal inhibitory concentration: 280 nM
Compound 4: the middle estimate sits 2.9-fold (0.46 log units) above what was measured; the whole stated range lies above it.
By their numbers in this assay, from the lowest: compounds 4, 3, 2 and 1 (each within the scatter of the next, the first and the last beyond it).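

In this assay, hydrogen on the aromatic carbon para to a large group gives a lower number than either oxygen-linked group seen there, by a modest step for difluoromethoxy (a 2.3-fold lower number from compound 2 to compound 4 (0.37 log units; beyond the scatter)) and for methoxy (a 2.9-fold lower number from compound 1 to compound 4 (0.46 log units; beyond the scatter)). Activity in this series therefore does not depend on either of those groups, something the earlier compounds, all substituted on that carbon, could not show; the unsubstituted phenyl also stays within the scatter of the 3,4-difluorophenyl (a 1.3-fold lower number from compound 3 to compound 4 (0.10 log units; within the scatter)), so adding those two fluorines brings no measurable change. No available evidence accounts for these steps.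

Open, from the compounds shown here alone, is how an amine, a carboxylic acid or a longer alkoxy chain on that carbon would behave. Also open, going by these compounds, is whether the sulfonamide nitrogen tolerates a methyl group.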